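The compounds below may be only part of what the source reports. "The series", "measured", "known", "first", "only" and "open" are said of these compounds alone.

Of the compounds shown here, three sharing one core have been tested in a functional assay on Jurkat cells (Homo sapiens); on this read-out lower numbers stand for stronger inhibition and higher numbers for weaker inhibition. Compound 1 `CC(C)[C@H](NC(=O)COc1cccc2ccccc12)C(=O)N[C@@H](CC(=O)O)C(=O)COc1ccc(-c2ccccc2)cc1` gives 87900 nM. Compound 2 `CC(C)[C@H](NC(=O)COc1cccc2ccccc12)C(=O)N[C@@H](CC(=O)O)C(=O)COc1ccc(C(N)=O)cc1` reaches only a limit of the assay, > 100000 nM. Compound 3 `CC(C)[C@H](NC(=O)COc1cccc2ccccc12)C(=O)N[C@@H](CC(=O)O)C(=O)COc1c(F)cc(F)cc1F` gives 6840 nM, the lowest number of the three.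

Compound 4 `CC(C)[C@H](NC(=O)COc1cccc2ccccc12)C(=O)N[C@@H](CC(=O)O)C(=O)COc1c(F)c(F)cc(F)c1F` has not yet been measured. It differs from compound 3 in one place: 2,3,5,6-tetrafluorophenyl in place of 2,4,6-trifluorophenyl on an oxygen on a saturated carbon. In words, 2,3,5,6-tetrafluorophenyl stands in place of 2,4,6-trifluorophenyl on an oxygen on a saturated carbon.

Two measured steps change this same group, and both are large: a 13-fold lower number from compound 1 to compound 3 (1.11 log units; beyond the scatter) and an at least 14-fold lower number from compound 2 to compound 3 (1.16 log units; beyond the scatter). Each of them, however, starts from a ring carrying no fluorine, 4-phenylphenyl or 4-carbamoylphenyl. Among the measured compounds shown here, compound 4 keeps a fluorinated ring, like compound 3 at 6840 nM, so no step of that size is expected, and none beyond the scatter. The expected step is a 1.4-fold lower number from compound 3 to compound 4 (0.14 log units; within the scatter). Compound 4 is estimated at 5000 nM, with an expected range of 1500 nM to 17000 nM.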

Compound 4, half-maximal inhibitory concentration: 4500 nM
The estimate for compound 4 lay 1.1-fold (0.05 log units) above the measured number; measured number inside the range.
By their numbers in this assay, from the lowest: compounds 4 and 3 (each within the scatter of the next); then compound 1. At a limit, above all of these: compound 2.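

A second fluorinated ring on this oxygen gives a 1.5-fold lower number from compound 3 to compound 4 (0.18 log units; within the scatter), so the change from 2,4,6-trifluorophenyl to 2,3,5,6-tetrafluorophenyl does not separate the two compounds. Set against the rings without fluorine, the new ring shows a 20-fold lower number from compound 1 to compound 4 (1.29 log units; beyond the scatter) and an at least 22-fold lower number from compound 2 to compound 4 (1.34 log units; beyond the scatter), which means the large gap no longer rests on compound 3 alone. The second of these steps is only a floor, and compound 2 stands at a limit rather than a number: the limit of > 100000 nM in this assay, at which 1 of the 4 values shown sits.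

The compounds shown do not tell whether a plain phenyl or a phenyl with a single fluorine would sit with the two fluorinated compounds or with compound 1. On these data alone, how a chlorine or a methoxy group on this ring would read also stays open.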